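Swapping the terminal aryl ring on two benzimidazole cores

A few compounds are considered here, and "the series" means these few. Any claim that something is new, unique, unknown or untested is made for them only; others in the source may bear on it.

Measured so far:
compound 1, `Cc1ccc2[nH]c(-c3ccc(-c4ccc(-c5cccc(Cl)c5)cc4)cc3)nc2c1`, gives 2800 nM
compound 2, `COc1ccc(-c2ccc(-c3ccc(-c4nc5cc(C)ccc5[nH]4)cc3)cc2)cc1OC`, gives 2130 nM
compound 3, `Oc1cccc2[nH]c(-c3ccc(-c4ccc(-c5cccc(Cl)c5)cc4)cc3)nc12`, gives 2800 nM

All three were tested in a functional assay on A2780 cells (Homo sapiens) for inhibition, read by sulforhodamine B assay; a lower number here means a stronger inhibitor of growth, a higher number a weaker inhibitor of growth. Compound 1 and compound 3 share the same terminal 3-chlorophenyl ring but differ in their core; the difference between the two cores is not broken down here, and their values sit level with each other. Compound 2 arises from compound 1 by the change (3,4-dimethoxyphenyl in place of 3-chlorophenyl on an aromatic carbon), which gave a 1.3-fold lower number from compound 1 to compound 2 (0.12 log units; within the scatter).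

Compound 4, `COc1ccc(-c2ccc(-c3ccc(-c4nc5c(O)cccc5[nH]4)cc3)cc2)cc1OC`, has not yet been measured. Among the measured compounds shown here, it arises from compound 3 by the change (3,4-dimethoxyphenyl in place of 3-chlorophenyl on an aromatic carbon), the same change as the one from compound 1 to compound 2, made at the same place.

Because the earlier instance of this change gave a 1.3-fold lower number from compound 1 to compound 2 (0.12 log units; within the scatter), the step from compound 3 to compound 4 is expected to be of similar size, namely a 1.3-fold lower number from compound 3 to compound 4 (0.10 log units; within the scatter). On that basis compound 4 is estimated at 2200 nM in this assay, with a range from 1000 nM to 4800 nM. This expectation rests on a single earlier pair and so carries the full uncertainty of a lone step lying within the scatter.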

Compound 4, concentration for 50% growth inhibition: 2710 nM
Compound 4: the middle estimate sits 1.2-fold (0.09 log units) below what was measured; low and high end bracket the measured number.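

In this assay, putting 3,4-dimethoxyphenyl in place of 3-chlorophenyl on the core of compound 3 gave a 1.0-fold lower number from compound 3 to compound 4 (0.01 log units; within the scatter) and so matched the earlier instance of the change: the same change on two cores in this assay, a 1.3-fold lower number (0.12 log units; within the scatter) from compound 1 to compound 2 and a 1.0-fold lower number (0.01 log units; within the scatter) from compound 3 to compound 4, 1.3-fold (0.10 log units) apart, within the scatter of two such steps. This shows that the change behaved alike on these two cores, but both steps lie within the scatter, so what carried over is the absence of a measurable step and not a real gain or loss in growth inhibition. With the 3,4-dimethoxyphenyl ring held fixed, exchanging the core gave a 1.3-fold higher number from compound 2 to compound 4 (0.10 log units; within the scatter) and that too lies within the scatter, so the pair of cores offers no sign that one alters the outcome of the change.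

As far as these compounds go, what remains open is whether a change that gives a step clearly beyond the scatter would also carry from one core to the other. A terminal ring bearing an amine or a carboxylic acid, for example, might test this, but the compounds shown cannot say how either would behave on these cores.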